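Methyl to methoxy on an aromatic carbon: compound 4 pending

The compounds below may be only part of what the source reports. "The series", "measured", "known", "first", "only" and "open" are said of these compounds alone.

Measured so far:
compound 1 `Cc1ccc(/C=C2\CCC/C(=C\c3ccccc3[N+](=O)[O-])C2=O)cc1` gives 11000 nM
compound 2 `COc1ccc(/C=C2\CCC/C(=C\c3ccccc3[N+](=O)[O-])C2=O)cc1` gives 26000 nM
compound 3 `Cc1ccc(/C=C2\CCC/C(=C\c3cccc([N+](=O)[O-])c3)C2=O)cc1` gives 38000 nM

All three numbers come from a functional assay on HL-60 cells (Homo sapiens) for cytotoxicity, with a stated time of 24 h; on this read-out higher numbers stand for lower toxicity in this test and lower numbers for higher toxicity in this test. Compound 1 and compound 2 differ by methoxy in place of methyl on an aromatic carbon, and that change produced a 2.4-fold higher number from compound 1 to compound 2 (0.37 log units; beyond the scatter). Compound 3 holds the same atoms as compound 1 joined differently; the difference between the two cores is not broken down here. Compound 3 and compound 2 lie within the scatter of each other, so no order between them is claimed.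

Compound 4 `COc1ccc(/C=C2\CCC/C(=C\c3cccc([N+](=O)[O-])c3)C2=O)cc1` awaits measurement. It differs from compound 3 by methoxy in place of methyl on an aromatic carbon, the same change as from compound 1 to compound 2. Set beside a 2.4-fold higher number from compound 1 to compound 2 (0.37 log units; beyond the scatter), the expected step in this assay is a 2.0-fold higher number from compound 3 to compound 4 (0.30 log units; within the scatter). This expectation rests on compound 1 and compound 2 alone, because their pair gave a 2.4-fold higher number from compound 1 to compound 2 (0.37 log units; beyond the scatter). For compound 4 the estimate is 75000 nM, ranging from 35000 nM to 160000 nM.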

Compound 4, half-maximal cytotoxic concentration: 7200 nM
For compound 4 the middle estimate is 10-fold (1.02 log units) above the measured one, outside the stated range (below it).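

Methoxy in place of methyl on an aromatic carbon brings a 5.3-fold lower number from compound 3 to compound 4 (0.72 log units; beyond the scatter) in this assay and so runs opposite to the step on the core of compound 1: the same change on two cores in this assay, a 2.4-fold higher number (0.37 log units; beyond the scatter) from compound 1 to compound 2 and a 5.3-fold lower number (0.72 log units; beyond the scatter) from compound 3 to compound 4, 12-fold (1.10 log units) apart, beyond the scatter of two such steps

The 4-methylphenyl to 4-methoxyphenyl change therefore cannot be carried from one of these cores to the other as a fixed step. Two pairs show only that the outcome depends on the core; they do not show what in the cores sets the difference, or how the change behaves on any further core.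

Open, on these data alone, is whether a hydroxy group or a chlorine in the same place would follow methoxy or methyl on each core. Also open, as far as these compounds go, is how either pair would respond with an amine in place of the nitro group.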